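This account rests on a few compounds, and the source may have more. Where it says the series, first, only, none or still open, it means among the compounds named here.

Measured so far in a functional assay on 786-0 cells (Homo sapiens) for cytotoxicity, read by sulforhodamine B assay, with a stated time of 48 h, tested at 10 uM; a higher number here means a weaker effect of the compound at the concentration tested, a lower number a stronger effect:
compound 1 `COc1ccc(-c2cc(/C=C/C(=O)c3ccc(N)cc3)[nH]n2)cc1`: -29%
compound 2 `COc1cc(-c2cc(/C=C/C(=O)c3ccc(N)cc3)[nH]n2)cc(OC)c1OC`: -19%

Compound 2 stands highest of the two numbers, but its nearest neighbour, compound 1, lies within the usual scatter of it, so the two values are not told apart. Compound 3 `COc1ccc(-c2cc(/C=C/C(=O)c3ccc(N)cc3)[nH]n2)cc1OC` has not yet been measured in this assay. From compound 2 it differs by hydrogen in place of methoxy on an aromatic carbon. Among the compounds with values here, no step between measured compounds is available as a guide; with both measured values so close, no step beyond the scatter is expected from compound 2 to compound 3. Compound 3 is expected to give about -24% in this assay, between -45% and 0%, an expected step of a number 5 percentage points lower from compound 2 to compound 3 (within the scatter).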

Compound 3, a percentage reported as activity, at one concentration (the size of the read-out at that concentration, not a potency): -48%
For compound 3 the middle estimate is 24 percentage points above the measured one; the measured number lies below the stated range.
By their numbers in this assay, from the lowest: compound 3; then compounds 1 and 2 (each within the scatter of the next).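

In this assay hydrogen in place of methoxy on this aromatic carbon gives a number 29 percentage points lower from compound 2 to compound 3 (beyond the scatter) and methoxy in place of hydrogen on another aromatic carbon gives a number 19 percentage points lower from compound 1 to compound 3 (beyond the scatter) so the number of methoxy groups alone does not set the read-out. Both steps end at compound 3, which has the lowest number of the three and thus the strongest effect at the concentration tested. Nothing shown explains either step. 

Open, as far as these compounds go, is whether a hydroxyl group or a chlorine atom on this aromatic carbon would stay near compound 3 or compound 2. From the compounds shown here alone, how far this holds with an amine other than the shared aniline amine also remains open.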